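A few compounds are considered here, and "the series" means these few. Any claim that something is new, unique, unknown or untested is made for them only; others in the source may bear on it.

Measured compounds in a functional assay on the whole organism for activation, with Mus musculus as the target; on this read-out lower numbers stand for an effect already at smaller amounts and higher numbers for an effect only at larger amounts of compound:
compound 1 `CCc1nc(N)c2nc(O)n(Cc3ccccc3)c2n1`: 3 mg/kg
compound 2 `Nc1nc(SCc2ccccc2)nc2c1nc(O)n2Cc1ccccc1`: a limit of the assay, > 1 mg/kg
compound 3 `CCCNc1nc(N)c2nc(O)n(Cc3ccccc3)c2n1`: 1 mg/kg

Of the two values that are real numbers, compound 3 holds the lower one; compound 1 stands nearest to it, and the step from compound 1 to compound 3 is a 3.0-fold lower number from compound 1 to compound 3 (0.48 log units; beyond the scatter). The value of compound 2 is only a limit (the limit of > 1 mg/kg in this assay, at which 1 of the 3 values shown sits), so the step that the limit leaves unreadable from compound 1 to compound 2 and the step of a number no higher from compound 2 to compound 3 (the limit leaves the size open) cannot be sized from what is shown.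

Compound 4 `Nc1ncnc2c1nc(O)n2Cc1ccccc1` differs from compound 3 in one place: hydrogen in place of propylamino on an aromatic carbon. For the measured compounds named here, only one measured step speaks to this carbon, a 3.0-fold lower number from compound 1 to compound 3 (0.48 log units; beyond the scatter), which shows that putting propylamino in place of ethyl there gives a modestly lower number. Going by the values given here, no measured compound carries a hydrogen at this carbon, so the loss of the whole group has no direct precedent among the three. Since the group appears to help, its removal is expected to move the number upward in this assay, with an estimated step of a 3.0-fold higher number from compound 3 to compound 4 (0.48 log units; beyond the scatter). Compound 4 is therefore expected to give about 3 mg/kg in this assay, with a range from 1 mg/kg to 10 mg/kg.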

Compound 4, minimum effective dose: 30 mg/kg
Compound 4: the middle estimate sits 10-fold (1.00 log units) below what was measured; the measured number lies above the stated range.
By their numbers in this assay, from the lowest: compound 3; then compound 1; then compound 4.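

On this aromatic carbon, between two ring nitrogen atoms, hydrogen in place of propylamino gives a 30-fold higher number from compound 3 to compound 4 (1.48 log units; beyond the scatter) in this assay, and hydrogen in place of ethyl gives a 10-fold higher number from compound 1 to compound 4 (1.00 log units; beyond the scatter). The earlier compounds had shown only a modest difference between two groups at this carbon; compound 4 now shows that, of the compounds with readable values, both with a group there have much lower numbers than the one with hydrogen, and that the presence of either group accounts for more of the difference than the choice between ethyl and propylamino. Compound 2 has only a limit, so the steps that touch it, including the one to compound 4, cannot be read: the limit of > 1 mg/kg in this assay, at which 1 of the 4 values shown sits.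

The compounds shown leave open whether butylamino would lower the number further, and whether a group as small as methyl or a plain amino group at this carbon would already recover most of the loss. They also leave open whether the linking nitrogen of propylamino matters apart from the chain, since ethyl and propylamino differ in both.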